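From azido to methylamino: a step away from a limit

A few compounds are considered here, and "the series" means these few. Any claim that something is new, unique, unknown or untested is made for them only; others in the source may bear on it.

Compound 1 `N#Cc1cc(=O)[nH]c(=O)n1[C@@H]1O[C@H](CO)[C@@H](O)[C@H]1O`: > 50000 nM
Compound 2 `O=c1cc(I)n([C@@H]2O[C@H](CO)[C@@H](O)[C@H]2O)c(=O)[nH]1`: 15300 nM
Compound 3 `[N-]=[N+]=Nc1cc(=O)[nH]c(=O)n1[C@@H]1O[C@H](CO)[C@@H](O)[C@H]1O`: > 50000 nM

These results come from a functional assay on ML1 cells (Homo sapiens) for antiproliferative activity, read by WST assay, with a stated time of 3 days; a lower number here means a stronger inhibitor, a higher number a weaker inhibitor. Compound 3 reads > 50000 nM, which is a limit of the assay and not a number. Compound 1 reads > 50000 nM, which is also a limit. Together they account for (the limit of > 50000 nM in this assay, at which 2 of the 3 values shown sit). Only compound 2 gives a true number, 15300 nM.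

Compound 4 `CNc1cc(=O)[nH]c(=O)n1[C@@H]1O[C@H](CO)[C@@H](O)[C@H]1O` changes one group of compound 3: methylamino in place of azido on an aromatic carbon. Three measured steps swap a group on the same aromatic carbon. Two involve iodo and are beyond the scatter: an at least 3.2-fold lower number from compound 1 to compound 2 (0.51 log units; beyond the scatter) and an at least 3.2-fold higher number from compound 2 to compound 3 (0.51 log units; beyond the scatter). The third cannot be sized: a step that the two limits leave unreadable from compound 1 to compound 3. None involves methylamino, so they offer only a loose guide. Only iodo has given a number here, so no clear gain is expected, and another limit is the likeliest outcome.

The expected change is a number no higher from compound 3 to compound 4 (the limit leaves the size open). For compound 4 the estimated value is 50000 nM, with an expected range from 15000 nM to 80000 nM.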

Compound 4, half-maximal inhibitory concentration: > 50000 nM
Compound 4 ended at the assay's limit (the forecaster's own chance of this, stated with the estimate: 75%); the middle value lies on the limit itself.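

In this assay compound 4 gives > 50000 nM, which is a limit of the assay and not a number. For the compounds shown here, putting methylamino in place of azido adds a hydrogen-bond donor on this aromatic carbon, yet the reading does not come off that limit, and the one step that can be sized is an at least 3.2-fold higher number from compound 2 to compound 4 (0.51 log units; beyond the scatter). The steps to compound 4 from compound 3 and from compound 1 cannot be read, and iodo remains the only group here with a true number: the limit of > 50000 nM in this assay, at which 3 of the 4 values shown sit.

Whether methylamino, azido and nitrile differ at all in strength stays hidden behind the limit. On these data alone, it also remains open whether a plain amine, a bromo or chloro group, or a longer chain such as ethylamino on this carbon would give a true number, as compound 2 does.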